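The source may hold more compounds than are shown below. What is called first, only, known or untested is meant among the compounds shown, and "the series" means these compounds.

Compound 1 `CNC(=O)c1cc(C(=O)NC2CC2)cc2c1OC[C@H]2c1cccc2[nH]ccc12`: >= 142 ug/mL
Compound 2 `CNC(=O)c1cc(C(=O)N[C@H]2[C@@H]3COC[C@@H]32)cc2c1OC[C@H]2c1ccccc1`: >= 165 ug/mL
Compound 3 `CNC(=O)c1cc(C(=O)Nc2cnn(C)c2)cc2c1OC[C@H]2c1ccccc1`: >= 189 ug/mL

In a physicochemical assay for solubility (on this read-out higher numbers stand for higher solubility and lower numbers for lower solubility), all three compounds are reported only as limits, not as numbers. Compound 3 therefore has no exact position, and its limit is >= 189 ug/mL.

Compound 4 `CNC(=O)c1cc(C(=O)NC2CC2)cc2c1OC[C@H]2c1ccccc1` has cyclopropyl in place of 1-methyl-1H-pyrazol-4-yl on an amide-type nitrogen. Among the compounds with values here, the only measured step at this place is a step that the two limits leave unreadable from compound 2 to compound 3, so it offers no size to carry over. Compound 1 also carries cyclopropyl on an amide-type nitrogen, and it too is a limit, at >= 142 ug/mL. With that limit as the closest guide, no change beyond the usual scatter is expected, and the estimated step is an at least 1.1-fold lower number from compound 3 to compound 4 (0.07 log units; that floor lies within the scatter). A limit rather than a number is also the most likely report for compound 4. The estimate for compound 4 is 160 ug/mL, with an expected range of 90 ug/mL to 210 ug/mL.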

Compound 4, solubility: >= 190 ug/mL
Compound 4: a limit, no number (the forecaster's own chance of this, stated with the estimate: 80%); middle value at least 1.1-fold (0.07 log units) from the limit.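

Within the data shown here, compound 4 is reported only as a limit in this assay, as are compound 1, compound 2 and compound 3, so no step to compound 4 can be read. The compounds shown leave open the actual value of each, and whether cyclopropyl in place of 1-methyl-1H-pyrazol-4-yl on an amide-type nitrogen shifts the read-out of this assay at all.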